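Iodo replacing phenyl on the fused five-membered ring

A few compounds are considered here, and "the series" means these few. Any claim that something is new, unique, unknown or untested is made for them only; others in the source may bear on it.

Compound 1 `Cc1ncnc2c1c(I)cn2[C@@H]1O[C@H](CO)[C@@H](O)[C@H]1O`: 13300 nM
Compound 2 `COc1ncnc2c1c(-c1ccoc1)cn2[C@@H]1O[C@H](CO)[C@@H](O)[C@H]1O`: 29400 nM
Compound 3 `COc1ncnc2c1c(-c1ccccc1)cn2[C@@H]1O[C@H](CO)[C@@H](O)[C@H]1O`: > 100000 nM

In an ADME assay on MRC5 cells (Homo sapiens), read by MTT assay, with a stated time of 72 h (on this read-out lower numbers stand for stronger inhibition and higher numbers for weaker inhibition), compound 3 gives only the limit > 100000 nM and no number, so it stands at the weak end of what was measured. Compound 4 `COc1ncnc2c1c(I)cn2[C@@H]1O[C@H](CO)[C@@H](O)[C@H]1O` differs by iodo in place of phenyl on an aromatic carbon. Going by the values given here, no measured step exchanges iodo for phenyl directly. Among the compounds with values here, the only measured step, an at least 3.4-fold higher number from compound 2 to compound 3 (0.53 log units; beyond the scatter), ran toward phenyl and ended at the limit (the limit of > 100000 nM in this assay, at which 1 of the 3 values shown sits). Compound 1, which carries iodo, gives 13300 nM in this assay. A move away from phenyl is therefore expected to lower the number, and the step of an at least 5.0-fold lower number from compound 3 to compound 4 (0.69 log units; beyond the scatter) is the estimate. Compound 4 is expected to give about 20000 nM, in the range 6000 nM to 70000 nM.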

Compound 4, half-maximal inhibitory concentration: 63000 nM
Compound 4: middle estimate off by 3.2-fold (0.50 log units), on the low side; measured number inside the range.
By their numbers in this assay, from the lowest: compound 1; then compound 2; then compound 4. At a limit, above all of these: compound 3.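

In this assay compound 3 gives only a limit, > 100000 nM. Iodo in place of phenyl gives an at least 1.5-fold lower number from compound 3 to compound 4 (0.20 log units; that floor lies within the scatter), so this floor alone does not separate the two groups at this aromatic carbon. Iodo does separate from furan-3-yl, with a 2.1-fold higher number from compound 2 to compound 4 (0.33 log units; beyond the scatter), and with iodo kept, methoxy in place of methyl gives a 4.7-fold higher number from compound 1 to compound 4 (0.68 log units; beyond the scatter).

The compounds shown leave open how an amine or a carboxylic acid on this aromatic carbon would compare with iodo. They also leave open whether the methoxy and methyl exchange gives a similar step with furan-3-yl or phenyl in place of iodo.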